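A few compounds are considered here, and "the series" means these few. Any claim that something is new, unique, unknown or untested is made for them only; others in the source may bear on it.

Measured so far:
compound 1 `O=C(Nc1ccc(OC(F)(F)F)cc1)c1cc(F)ccc1O`, 850 nM
compound 2 `N#Cc1ccc(NC(=O)c2cc(Br)ccc2O)cc1`, 620 nM
compound 3 `N#Cc1ccc(NC(=O)c2cc(-c3cccnc3)ccc2O)cc1`, 7960 nM

All three numbers come from a functional assay on HL-60 cells (Homo sapiens) for cytotoxicity, read by luminescence and CellTiter-Glo, with a stated time of 3 days; on this read-out higher numbers stand for weaker inhibition and lower numbers for stronger inhibition. Compound 3 gives the highest of the three; compound 1 stands nearest and compound 2 furthest, both gaps beyond the scatter. Compound 4 `N#Cc1ccc(NC(=O)c2cc(F)ccc2O)cc1` differs from compound 3 in one place: fluoro in place of pyridin-3-yl on an aromatic carbon. Going by the values given here, the only measured step at this position is a 13-fold higher number from compound 2 to compound 3 (1.11 log units; beyond the scatter), where pyridin-3-yl entered. Compound 4 removes pyridin-3-yl again, and compound 1, which also carries fluoro on an aromatic carbon of the shared core, gives 850 nM, close to compound 2. A large downward step in this assay is therefore expected, an 11-fold lower number from compound 3 to compound 4 (1.06 log units; beyond the scatter). Compound 4 is estimated at 700 nM, range 300 nM to 1600 nM.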

Compound 4, half-maximal inhibitory concentration: 1420 nM
Compound 4: the middle estimate sits 2.0-fold (0.31 log units) below what was measured; low and high end bracket the measured number.
By their numbers in this assay, from the lowest: compounds 2, 1 and 4 (each within the scatter of the next, the first and the last beyond it); then compound 3.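

In this assay fluoro recovers only part of the loss seen with pyridin-3-yl (a 5.6-fold lower number from compound 3 to compound 4 (0.75 log units; beyond the scatter)). The two halogens at this position also separate, fluoro against bromo (a 2.3-fold higher number from compound 2 to compound 4 (0.36 log units; beyond the scatter)). With fluoro on the shared core, cyano and trifluoromethoxy are not told apart (a 1.7-fold higher number from compound 1 to compound 4 (0.22 log units; within the scatter)). No data here explain these steps.

Open, from the compounds shown here alone, is where chloro or methoxy would fall relative to fluoro and bromo at this position. Also open, going by these compounds, is whether an aminomethyl group or a carboxylic acid would be tolerated there.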